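This account rests on a few compounds, and the source may have more. Where it says the series, first, only, none or still open, it means among the compounds named here.

Measured compounds in a functional assay for antagonist activity at transient receptor potential cation channel subfamily V member 1 (Homo sapiens), read by FLIPR and calcium flux; on this read-out higher numbers stand for weaker inhibition and lower numbers for stronger inhibition:
- compound 2, `O=C1COc2ccc(NC(=O)C3CCN(c4cccc(Br)c4)CC3)cc2N1`: 330 nM
- compound 3, `COC(=O)CC1Oc2ccc(NC(=O)C3CCN(c4cc(F)cc(F)c4)CC3)cc2NC1=O`: 890 nM
- compound 1, `CC(=O)N1CCc2cc(NC(=O)C3CCN(c4cccc(C(F)(F)F)c4)CC3)ccc21`: > 9000 nM (a limit of this assay, not a number)

Compound 2 gives the lower of the two numbers in this assay. Its nearest neighbour is compound 3, whose value sits higher by a margin beyond the usual scatter; the two also differ in their cores, so the gap cannot be tied to the aryl group alone. Compound 1 returns only a limit, (the limit of > 9000 nM in this assay, at which 1 of the 3 values shown sits), and is not compared further.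

Compound 4, `O=C1COc2ccc(NC(=O)C3CCN(c4cc(F)c(F)c(F)c4)CC3)cc2N1`, keeps the core of compound 2 and changes the aryl group on the piperidine nitrogen: 3,4,5-trifluorophenyl in place of 3-bromophenyl on an amine nitrogen in a ring. For the measured compounds named here, no measured pair in the set isolates this change. Going by the values given here, the only other halogenated aryl group seen, the 3,5-difluorophenyl of compound 3, comes with a different core, so it gives direction only loosely.

Expectation: a step from compound 2 to compound 4 of a 1.7-fold higher number from compound 2 to compound 4 (0.22 log units; within the scatter), most likely a modest loss of potency, possibly none beyond the scatter. Compound 4 is estimated at 550 nM in this assay, within a range of 150 nM to 2000 nM.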

Compound 4, half-maximal inhibitory concentration: 59 nM
Compound 4: the middle estimate sits 9.3-fold (0.97 log units) above what was measured; the measured number lies below the stated range.
By their numbers in this assay, from the lowest: compound 4; then compound 2; then compound 3. At a limit, above all of these: compound 1.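

In this assay, the aryl group on the amine nitrogen of the six-membered non-aromatic ring proves to be a position that moves the number on its own: with the core of compound 2 held fixed, 3,4,5-trifluorophenyl in place of 3-bromophenyl gives a 5.6-fold lower number from compound 2 to compound 4 (0.75 log units; beyond the scatter). For the compounds shown here, this is the first comparison that differs in one place only, so it shows what the earlier compounds, with their differing cores, could not; it also shows that a change among halogenated phenyl groups alone can carry a step beyond the scatter. The single pair exchanges bromine for three fluorines at once, and no measurement shown here gives a reason for the step.

Going by these compounds, whether the step carries over to other cores stays open, since the aryl groups of compound 1 and compound 3 have no partner on the core of compound 2. Also open, on these data alone, is how a nitrile or a methoxy group on that phenyl ring would read on the same core in this assay.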